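This account rests on a few compounds, and the source may have more. Where it says the series, first, only, none or still open, it means among the compounds named here.

Compound 3 `O=C(Nc1ccc(S(=O)(=O)Nc2ccccc2)cc1)c1ccc(Cl)cc1Br` carries a 2-bromo-4-chlorophenyl on the carbonyl carbon of a core it shares with compound 1 `O=C(Nc1ccc(S(=O)(=O)Nc2ccccc2)cc1)c1cc(F)c(Cl)cc1F` and compound 2 `N#Cc1ccc(C(=O)Nc2ccc(S(=O)(=O)Nc3ccccc3)cc2)c(F)c1`. In a functional assay on HEK293 cells for agonist activity at probable G-protein coupled receptor 27 (Homo sapiens), read by a luciferase reporter and beta-arrestin recruitment, with a stated time of 10 min (on this read-out lower numbers stand for an effect already at smaller amounts and higher numbers for an effect only at larger amounts of compound), compound 3 gives 1020 nM, the highest of the three numbers: compound 1 gives 141 nM and compound 2 gives 229 nM. Compound 4 `O=C(Nc1ccc(S(=O)(=O)Nc2ccccc2)cc1)c1ccc(I)cc1F` has not yet been measured; it differs from compound 3 in one place, (2-fluoro-4-iodophenyl in place of 2-bromo-4-chlorophenyl on a carbonyl carbon).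

Three measured steps frame this change. The step of a 7.2-fold higher number from compound 1 to compound 3 (0.86 log units; beyond the scatter) and the step of a 4.5-fold higher number from compound 2 to compound 3 (0.65 log units; beyond the scatter) both run toward the 2-bromo-4-chlorophenyl and both lie beyond the scatter, while a 1.6-fold higher number from compound 1 to compound 2 (0.21 log units; within the scatter) stays within it. Compound 4 keeps the fluorine that compound 1 and compound 2 carry on the ring at the carbonyl carbon and drops the bromine of compound 3, so the change runs back in the direction of those two lower numbers. A step down is therefore expected, of a size like the reverse of the measured ones, which would be a 4.1-fold lower number from compound 3 to compound 4 (0.61 log units; beyond the scatter) in this assay. Compound 4 is accordingly estimated at 250 nM in this assay, within a range from 80 nM to 800 nM.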

Compound 4, half-maximal effective concentration: 5130 nM
Estimate against measurement, compound 4: 21-fold (1.31 log units) below; measured number above the stated range.
By their numbers in this assay, from the lowest: compounds 1 and 2 (each within the scatter of the next); then compound 3; then compound 4.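

In this assay, the 2-fluoro-4-iodophenyl on the carbonyl carbon does not join the lower numbers of the other fluorine-bearing rings: replacing the 2-bromo-4-chlorophenyl gives a 5.0-fold higher number from compound 3 to compound 4 (0.70 log units; beyond the scatter) and moves the series further up, not down. Fluorine on this ring is therefore not enough to hold the number low, since iodo in place of cyano on an aromatic carbon gives a 22-fold higher number from compound 2 to compound 4 (1.35 log units; beyond the scatter), while the change from the 4-chloro-2,5-difluorophenyl gives a 36-fold higher number from compound 1 to compound 4 (1.56 log units; beyond the scatter), both large steps and both larger than any step among the earlier compounds. Nothing available here accounts for this rise.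

The compounds shown leave open whether the iodine alone drives the change, since compound 4 is not paired with a 4-chloro-2-fluorophenyl analogue, which would separate iodine from chlorine on an otherwise identical ring. Going by these compounds, it also remains open how the number would respond if a methoxy group, an amine or a carboxylic acid stood in place of the iodo on an aromatic carbon.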